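The source may hold more compounds than are shown below. What is called first, only, known or untested is meant among the compounds shown, and "the series" means these compounds.

Compound 1, `C=CC1=C(C(=O)NCc2ccccc2)C(c2ccc(OC)cc2)OC1`: in a functional assay on A549 cells (Homo sapiens) for cytotoxicity, read by MTT assay, with a stated time of 24 h (a lower number here means a stronger inhibitor, a higher number a weaker inhibitor), compound 1 gives > 100000 nM, which is a limit of the assay and not a number.
Compound 2, `C=CC1=C(C(=O)O)C(c2ccc(F)cc2)OC1`: in this assay compound 2 gives > 100000 nM, again a limit of the assay.
Compound 3, `C=CC1=C(C(=O)NCCCCC)C(c2ccc(Cl)c(Cl)c2)OC1`: in this assay compound 3 gives > 100000 nM, also only a limit.

Compound 3 therefore has no measured number to stand on; its result sits at the limit of > 100000 nM in this assay, at which 3 of the 3 values shown sit, and the two other compounds do the same, so no ordering among the three can be drawn from what is shown. The step taken from compound 3 leads to compound 4, `C=CC1=C(C(=O)NCCC)C(c2ccc(Cl)c(Cl)c2)OC1`, which is not yet measured. The change is hydrogen in place of ethyl on a saturated chain carbon, three bonds along the chain from an amide-type nitrogen, in words hydrogen in place of ethyl on a saturated chain carbon, three bonds along the chain from an amide-type nitrogen. For the measured compounds named here, no step between measured compounds is available to size this change. With all three measured values resting at a limit, the expectation in this assay is no step beyond the scatter in either direction, and the most probable outcome is that the assay again reports only a limit.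

For compound 4 the estimate is 150000 nM, with a range from 50000 nM to 1000000 nM. The step this estimate implies, a step that the limit leaves unreadable from compound 3 to compound 4, is expected to be within the scatter.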

Compound 4, half-maximal inhibitory concentration: > 100000 nM
Compound 4 ended at the assay's limit; the forecaster's own chance of this, stated with the estimate: 85%; the middle value does not contradict the limit.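

No size can be read for the step between compound 3 and compound 4, as both results are limits of this assay and not numbers: the limit of > 100000 nM in this assay, at which 4 of the 4 values shown sit.

The compounds shown leave open whether any change to this shared core would give a measurable number in this assay, and how large the effect of such a change would be.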